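Same swap, weaker core: estimating compound 4

The source may report more compounds than this note shows. Statements on the series, on what has been measured and on what is new or still open speak of the compounds shown alone.

Three small compounds have been measured in an assay for inhibition of alcohol dehydrogenase (Equus caballus), read by spectrophotometry, in the presence of a further agent that is not named here (a higher number here means weaker binding, a lower number tighter binding), and a fourth is still to be measured. Compound 1 `ClCCCc1cn[nH]c1` gives 20 nM in this assay. Compound 3 `OCc1cn[nH]c1` shares its core and differs in one place: hydroxy in place of 2-chloroethyl on a saturated chain carbon bound to an aromatic carbon. In this assay compound 3 gives 3600 nM. That single change made a large step, a 180-fold higher number from compound 1 to compound 3 (2.26 log units; beyond the scatter), so the hydroxy compound binds far more weakly than the 2-chloroethyl compound on this core.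

Compound 2 `ClCCCc1cc[nH]n1` is built from the same atoms as compound 1, joined differently; the difference between the two cores is not broken down here. In this assay compound 2 gives 40000 nM, the highest of the three numbers and well above compound 3 as well as compound 1.

Compound 4 `OCc1cc[nH]n1` stands to compound 2 as compound 3 stands to compound 1: hydroxy in place of 2-chloroethyl on a saturated chain carbon bound to an aromatic carbon. The place is described in the same words in both cases, so this is the same change, now made on the core of compound 2. Going by the values given here, the only guide to its size is the measured pair, where a 180-fold higher number from compound 1 to compound 3 (2.26 log units; beyond the scatter) was seen, while compound 2 already starts from a much higher number than compound 1, and such a weak starting point leaves less room for a further loss to be read cleanly. The expected step from compound 2 to compound 4 is therefore a 38-fold higher number from compound 2 to compound 4 (1.57 log units; beyond the scatter), and compound 4 is estimated at 1500000 nM, between 200000 nM and 10000000 nM.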

Compound 4, dissociation constant: 150000 nM
For compound 4 the middle estimate is 10-fold (1.00 log units) above the measured one; measured number below the stated range.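

On the core of compound 2, putting hydroxy in place of 2-chloroethyl produces a 3.8-fold higher number from compound 2 to compound 4 (0.57 log units; beyond the scatter) in this assay, so binding again gets weaker, but only by a modest step. A newcomer might hope that a change has a fixed cost that can be carried from one core to another, yet the two pairs in this series do not support this, as the size of the step depends clearly on the core that carries it: the same change on two cores in this assay, a 180-fold higher number (2.26 log units; beyond the scatter) from compound 1 to compound 3 and a 3.8-fold higher number (0.57 log units; beyond the scatter) from compound 2 to compound 4, 48-fold (1.68 log units) apart, beyond the scatter of two such steps What this shows is limited to two pairs: the number rises in both, but the size does not transfer, and two pairs cannot explain why the steps differ or give a rule for any other core.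

The compounds shown leave open how an amine, a carboxylic acid or a longer chain, placed on a saturated chain carbon bound to an aromatic carbon, would behave on these two cores. They also leave open whether such groups would show a similar gap between the cores or whether this gap belongs only to the exchange of 2-chloroethyl for hydroxy.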